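Cytotoxicity on kidney cells: amide aryl swap in compound 4

The source may report more compounds than this note shows. Statements on the series, on what has been measured and on what is new or still open speak of the compounds shown alone.

Three amides sharing one core have been tested in an ADME assay on LLC-MK2 cells (Macaca mulatta) for cytotoxicity, read by spectrophotometry and crystal violet staining, with a stated time of 4 days; a lower number here means that less compound is tolerated, a higher number that more compound is tolerated. Compound 1, `CC(C)n1ncc2c(C(=O)Nc3cccc(F)c3)cc(-c3cccs3)nc21`, gives only a limit there, > 200000 nM; this is the limit (the limit of > 200000 nM in this assay, at which 1 of the 3 values shown sits). Compound 2, `CC(C)n1ncc2c(C(=O)Nc3ccncc3)cc(-c3cccs3)nc21`, gives 6300 nM in this assay, and compound 3, `CC(C)n1ncc2c(C(=O)Nc3cccc(S(N)(=O)=O)c3)cc(-c3cccs3)nc21`, gives 25000 nM. Among the two numbers compound 3 stands highest, with compound 2 as the nearest value, a 4.0-fold higher number from compound 2 to compound 3 (0.60 log units; beyond the scatter). Against compound 1, the step is an at least 8.0-fold lower number from compound 1 to compound 3 (0.90 log units; beyond the scatter).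

Compound 4, `CC(C)n1ncc2c(C(=O)Nc3cc(C(N)=O)ccc3F)cc(-c3cccs3)nc21`, is not yet measured. It differs from compound 3 by 5-carbamoyl-2-fluorophenyl in place of 3-sulfamoylphenyl on an amide-type nitrogen. Among the measured compounds shown here, two measured steps bear on this: the change from compound 1 to compound 3, an at least 8.0-fold lower number from compound 1 to compound 3 (0.90 log units; beyond the scatter), and the change from compound 2 to compound 3, a 4.0-fold higher number from compound 2 to compound 3 (0.60 log units; beyond the scatter). Compound 4 keeps a fluoro substituent on the aryl amide, as compound 1 does, while the carbamoyl brings back one hydrogen-bond donor as the sulfamoyl of compound 3 did. The expected step in this assay is therefore upward but small, a 1.6-fold higher number from compound 3 to compound 4 (0.20 log units; within the scatter), and a result close to compound 3 would lie within the scatter. The estimate for compound 4 in this assay is 40000 nM, with a range from 12000 nM to 150000 nM; a limit like that of compound 1 is possible but not expected.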

Compound 4, half-maximal cytotoxic concentration: 25000 nM
Compound 4: middle estimate off by 1.6-fold (0.20 log units), on the high side, and the stated range covers the measured number.
By their numbers in this assay, from the lowest: compound 2; then compounds 3 and 4 (each within the scatter of the next). At a limit, above all of these: compound 1.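

In this assay, the exchange on the amide-type nitrogen gives no change at the digits printed from compound 3 to compound 4 (within the scatter), so the sulfamoyl of compound 3 is not needed to reach this level: a carbamoyl with a fluoro on the same phenyl ring serves equally well here. Against the pyridin-4-yl group, the new aryl group gives a 4.0-fold higher number from compound 2 to compound 4 (0.60 log units; beyond the scatter), matching the step already seen for compound 3, so both substituted phenyl amides with a hydrogen-bond donor on the substituent now read on the same side of compound 2. Keeping a fluoro on the aryl group does not bring back the reading of compound 1, as an at least 8.0-fold lower number from compound 1 to compound 4 (0.90 log units; beyond the scatter) shows, and that step has only one bound since the value of compound 1 is a limit and not a number: the limit of > 200000 nM in this assay, at which 1 of the 4 values shown sits.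

The compounds shown do not separate the contribution of the carbamoyl from that of the fluoro, since compound 4 differs from compound 3 in both at once. They also leave open how an aryl group bearing an amine or a carboxylic acid at this place would read in this assay.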